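The compounds below may be only part of what the source reports. "The series", "measured", "known", "first", "only" and "open" are said of these compounds alone.

Working notes on the series. Compound 1 `c1ccc2c(c1)CN[C@@H](CN(CC[C@@H]1CCCNC1)[C@H]1CCCc3cccnc31)C2` is the stronger of the two measured entries: in a functional assay on CCRF-CEM cells for antagonist activity at C-X-C chemokine receptor type 4 (Homo sapiens), read by calcium flux, with stated times of 25 min and 90 s (a higher number here means a weaker inhibitor, a lower number a stronger inhibitor), compound 1 gives 161 nM. Compound 2 `c1cnc2c(c1)CN[C@H](CN(CCCN1CCNCC1)[C@H]1CCCc3cccnc31)C2` differs from compound 1 in more than one place, so the pair is not a single step; in this assay compound 2 gives 2640 nM, a higher number that lies beyond the scatter, which leaves compound 1 with the lowest number of the two.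

Compound 3 `NC(=O)N1CCN(CCCN(C[C@H]2Cc3ccccc3CN2)[C@H]2CCCc3cccnc32)CC1` is the next entry and has not yet been measured in this assay. Against compound 1 the change is (4-carbamoylpiperazin-1-yl)methyl in place of piperidin-3-yl on a saturated chain carbon, two bonds along the chain from an amine nitrogen. Among the compounds with values here, no measured pair isolates this change, so the size of the step has to be expected rather than read off. The one piece of context is that compound 2, whose chain also carries a piperazine, gives 2640 nM, though that compound also changes the core. A moderate loss is expected, so the step from compound 1 to compound 3 is estimated at a 3.1-fold higher number from compound 1 to compound 3 (0.49 log units; beyond the scatter). For compound 3 the estimate in this assay is 500 nM, with a range from 150 nM to 1600 nM.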

Compound 3, half-maximal inhibitory concentration: 959 nM
The estimate for compound 3 lay 1.9-fold (0.28 log units) below the measured number, and the stated range covers the measured number.
By their numbers in this assay, from the lowest: compound 1; then compound 3; then compound 2.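

In this assay, within the data shown here, (4-carbamoylpiperazin-1-yl)methyl in place of piperidin-3-yl on a saturated chain carbon, two bonds along the chain from an amine nitrogen, gives a 6.0-fold higher number from compound 1 to compound 3 (0.77 log units; beyond the scatter), the first step at this position that can be read from a single change. The position therefore responds to what is attached there, although the printed loss is only modest even though the entering group has more heavy atoms, two hetero atoms in its six-membered non-aromatic ring and a double bond outside aromatic rings, and the leaving group's defined stereocentre is gone. No measurement at hand accounts for the size of this step.

The step replaces the ring, the carbamoyl group and the link to the chain together, so it cannot show which of these parts carries the loss. Among these compounds, a morpholin-4-ylmethyl group or a piperidin-4-yl group in the same place, on the core of compound 1, would help to separate these parts, and the single step available gives no trend across groups at this position.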